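The source may hold more compounds than are shown below. What is called first, only, known or untested is meant among the compounds shown, and "the series" means these compounds.

Among the compounds with values here, in a physicochemical assay for solubility, in phosphate buffer, with a stated time of 24 h, at pH 7.4 (on this read-out higher numbers stand for higher solubility and lower numbers for lower solubility), compound 1 `COc1ccc(-c2ccc(OCc3cc(C(=O)NS(=O)(=O)c4ccccc4)oc3C)cc2)c(C)c1` gives 20 ug/mL as the higher of the two numbers so far, and compound 2 `Cc1oc(C(=O)NS(=O)(=O)c2ccccc2)cc1COc1ccc(-c2ccccc2)cc1` gives 2 ug/mL on the same read-out. The change to compound 3 `COc1ccc(-c2ccc(OCc3cc(C(=O)NS(=O)(=O)c4c(C)noc4C)oc3C)cc2)c(C)c1` is 3,5-dimethyl-1,2-oxazol-4-yl in place of phenyl on a sulfonyl sulfur and the rest of compound 1 stays as it is. Within the data shown here, the one measured step is a 10-fold lower number from compound 1 to compound 2 (1.00 log units; beyond the scatter) and lies beyond the scatter, but it swaps 4-methoxy-2-methylphenyl for phenyl on an aromatic carbon and leaves the sulfonyl sulfur untouched. Among the measured compounds shown here, no measured step covers the group on the sulfonyl sulfur, so that step shows only that this read-out can move. In this assay no step beyond the scatter is therefore expected, with a slight lean towards a higher number. The expected change is a 1.5-fold higher number from compound 1 to compound 3 (0.18 log units; within the scatter) on this estimate. For compound 3 the estimated value is 30 ug/mL with 8 ug/mL to 100 ug/mL as the expected span.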

Compound 3, solubility: 200 ug/mL
Compound 3: the middle estimate sits 6.7-fold (0.82 log units) below what was measured; the whole stated range lies below it.
By their numbers in this assay, from the lowest: compound 2; then compound 1; then compound 3.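

In this assay the sulfonyl sulfur now counts as a place where the read-out responds: 3,5-dimethyl-1,2-oxazol-4-yl in place of phenyl gives a 10-fold higher number from compound 1 to compound 3 (1.00 log units; beyond the scatter) and so moves the number beyond the scatter. Within the data shown here, the only earlier step, a 10-fold lower number from compound 1 to compound 2 (1.00 log units; beyond the scatter) at an aromatic carbon, said nothing about this place, so compound 1 now has two places with a step beyond the scatter. No measurement at hand accounts for the new step.

Open, on these data alone, is whether the whole 3,5-dimethyl-1,2-oxazol-4-yl group is needed for this step, or whether an unsubstituted 1,2-oxazol-4-yl or a pyridin-3-yl on the sulfonyl sulfur would give a step of similar size. Also open, as far as these compounds go, is whether the same exchange on compound 2 would move the number as far.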